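A few compounds are considered here, and "the series" means these few. Any claim that something is new, unique, unknown or untested is made for them only; others in the source may bear on it.

The measured compounds:

Compound 1, `Nc1nc(Cl)c(-c2nccs2)c(N[C@@H]2C[C@H](CO)[C@@H](O)[C@H]2O)n1`.
Compound 2, `Nc1nc(Cl)c(-c2nc3ccccc3s2)c(N[C@@H]2C[C@H](CO)[C@@H](O)[C@H]2O)n1`.
Compound 3, `Cc1nc(NC(C)(C)C)nc(N[C@@H]2C[C@H](CO)[C@@H](O)[C@H]2O)c1-c1nc2ccccc2s1`.

In an ADME assay on cells (Homo sapiens) for cytotoxicity, read by polymerase chain reaction, with a stated time of 3 days (a lower number here means that less compound is tolerated, a higher number that more compound is tolerated), compound 1 gives only a limit, > 25000 nM, which is the limit of > 25000 nM in this assay, at which 1 of the 3 values shown sits. In this assay compound 2 gives 14000 nM. In this assay compound 3 gives 12000 nM. Among the measured compounds shown here, the one change between measured compounds, 1,3-benzothiazol-2-yl in place of 1,3-thiazol-2-yl on an aromatic carbon, gave an at least 1.7-fold lower number from compound 1 to compound 2 (0.25 log units; that floor lies within the scatter). Compound 3 has the lowest of the two numbers, but the numbers for compound 2 and compound 3 lie within the scatter of each other, so no order between them is claimed.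

Compound 4, `Cc1nc(NCCC(F)(F)F)nc(N[C@@H]2C[C@H](CO)[C@@H](O)[C@H]2O)c1-c1nc2ccccc2s1`, differs from compound 3 by 3,3,3-trifluoropropyl in place of tert-butyl on a nitrogen on an aromatic ring. For the measured compounds named here, no measured step touches this nitrogen, so nothing among the measured compounds indicates a change in tolerated concentration beyond the scatter. Compound 4 is therefore estimated to give 12000 nM, between 6000 nM and 25000 nM. The expected step is no change at the digits printed from compound 3 to compound 4 (within the scatter).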

Compound 4, half-maximal cytotoxic concentration: 9000 nM
The estimate for compound 4 lay 1.3-fold (0.12 log units) above the measured number, within the range that was stated.
By their numbers in this assay, from the lowest: compounds 4, 3 and 2 (each within the scatter of the next). At a limit, above all of these: compound 1.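

Replacing tert-butyl with 3,3,3-trifluoropropyl on the nitrogen on the aromatic ring was read in this assay as a single step (a 1.3-fold lower number from compound 3 to compound 4 (0.12 log units; within the scatter)). Among the compounds shown here, this is the only measured step that touches this nitrogen, and it shows that the tolerated concentration does not separate these two groups, one all carbon and the other carrying fluorine. Nothing among the values shown gives a cause for this result.

On these data alone, whether a different group on this nitrogen, such as a chain ending in an amine or a carboxylic acid, or a longer chain, would move the number beyond the scatter remains open. Also open, as far as these compounds go, is whether the same exchange would give a similar result with 1,3-thiazol-2-yl in place of 1,3-benzothiazol-2-yl.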